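Compound 4 from compound 2: ring swap on the chain

The source may report more compounds than this note shows. Statements on the series, on what has been measured and on what is new or still open speak of the compounds shown alone.

The series is followed in a functional assay on A549 cells (Homo sapiens) for antiproliferative activity, read by MTT assay, with a stated time of 12 h; a lower number here means a stronger inhibitor, a higher number a weaker inhibitor. Compound 2 `COc1cc(OC)c2c(=O)cc(/C=C/c3ccncc3)oc2c1` gives only a limit of the assay there, > 40000 nM. Compound 1 `COc1ccc2oc(/C=C/c3ccc(OC(F)(F)F)cc3)cc(=O)c2c1` likewise sits at a limit of the assay, > 40000 nM. Compound 3 `COc1cccc2oc(/C=C/c3ccc(OC(F)(F)F)cc3)cc(=O)c12` also returns a limit of the assay, > 40000 nM. Going by the values given here, compound 2 therefore stands nowhere apart from the rest: every value obtained so far is a limit, as the limit of > 40000 nM in this assay, at which 3 of the 3 values shown sit, records, and no measured pair that differs in a single place exists, so no step of known size is available in this assay.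

Compound 4 `COc1cc(OC)c2c(=O)cc(/C=C/c3ccc(Cl)cc3)oc2c1` is not yet measured. It differs from compound 2 by 4-chlorophenyl in place of pyridin-4-yl on a double-bonded chain carbon bound to a double-bonded chain carbon. With all measured values resting at the same limit, nothing in the series ties the ring on the chain to a gain or loss of antiproliferative potency, and the expectation is that this assay again returns a limit or a number near it. The expected step that the limit leaves unreadable from compound 2 to compound 4 is none beyond the scatter. Compound 4 is accordingly estimated at 45000 nM in this assay, within a range from 10000 nM to 200000 nM, with a good chance that only a limit is read.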

Compound 4, half-maximal inhibitory concentration: > 40000 nM
Compound 4: no number, only a limit; the forecaster's own chance of this, stated with the estimate: 75%; the middle value is on the limit's open side.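

In this assay compound 4 gives only a limit, > 40000 nM. Compound 2 also sits at a limit, so no step can be read between compound 2 and compound 4, and 4-chlorophenyl in place of pyridin-4-yl has no measurable size here: the limit of > 40000 nM in this assay, at which 4 of the 4 values shown sit.

The compounds shown leave open whether any ring on the chain would give an actual number in this assay.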